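This account rests on a few compounds, and the source may have more. Where it says the series, first, only, none or still open, it means among the compounds named here.

Compound 2 `CC(=O)Nc1ccc(-c2nnc(C3(c4ccc(Cl)cc4)CCC3)n2C)c(Cl)c1` stands only at a limit in an assay on isolated protein for inhibition of 11-beta-hydroxysteroid dehydrogenase type 2 (Mus musculus); a higher number here means a weaker inhibitor, a lower number a stronger inhibitor: for compound 2 the read-out is > 4000 nM, a limit of the assay rather than a number. Compound 1 `Cn1c(-c2ccc(-c3cncnc3)cc2)nnc1C1(c2ccc(Cl)cc2)CCC1` is likewise reported as a limit, > 4000 nM. Compound 3 `Cc1noc(C)c1-c1ccc(-c2nnc(C3(c4ccc(Cl)cc4)CCC3)n2C)cc1` also gives a limit, > 4000 nM. All three shown values sit at the limit of > 4000 nM in this assay, at which 3 of the 3 values shown sit, so the single step between measured compounds, a step that the two limits leave unreadable from compound 1 to compound 3, cannot be read. The change leading to compound 4 `Cn1c(-c2ccc(C(N)=O)cc2Cl)nnc1C1(c2ccc(Cl)cc2)CCC1` is carbamoyl in place of acetamido on an aromatic carbon. No measured step bears on this change, and none of the shown steps is readable, so no direction beyond the scatter can be expected. Compound 4 is expected to stay at the limit, estimated at 8000 nM with a range from 3000 nM to 30000 nM. The step this estimate implies, a step that the limit leaves unreadable from compound 2 to compound 4, is expected to be small.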

Compound 4, half-maximal inhibitory concentration: > 4000 nM
Compound 4 ended at the assay's limit; the forecaster's own chance of this, stated with the estimate: 85%; the middle value is on the limit's open side.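

Compound 4 is reported only as a limit, > 4000 nM, so its step from compound 2 cannot be read: the limit of > 4000 nM in this assay, at which 4 of the 4 values shown sit.

The compounds shown leave open what true value lies behind each limit, and so how carbamoyl and acetamido compare.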